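A few compounds are considered here, and "the series" means these few. Any claim that something is new, unique, unknown or untested is made for them only; others in the source may bear on it.

Measured so far:
compound 1 `CC1CCN(c2ccc3cc(NC(=O)CCc4ccc(C(F)(F)F)cc4)ccc3n2)C1` — in an assay on isolated protein for displacement of a labelled ligand from melanin-concentrating hormone receptor 1 (Homo sapiens) (on this read-out lower numbers stand for stronger inhibition and higher numbers for weaker inhibition), compound 1 gives 2 nM
compound 2 `O=C(CCc1ccc(C(F)(F)F)cc1)Nc1ccc2nc(N3CC4CC3CO4)ccc2c1` — in this assay compound 2 gives 13 nM

Among the compounds with values here, compound 2 stands highest of the two numbers; the single measured step, a 6.5-fold higher number from compound 1 to compound 2 (0.81 log units; beyond the scatter), lies beyond the scatter. Compound 3 `O=C(CCc1ccc(C(F)(F)F)cc1)Nc1ccc2nc(N3CCCCC3)ccc2c1` differs from compound 2 by a group of 6 heavy atoms (5 carbon, 1 nitrogen; one six-membered non-aromatic ring with 1 hetero atom) in place of a group of 7 heavy atoms (5 carbon, 1 nitrogen, 1 oxygen; 2 five-membered non-aromatic rings with 1 hetero atom each), on an aromatic carbon. Within the data shown here, only that one step bears on the change: there the group that now leaves entered in place of a single saturated ring and the number rose. Reversing toward a single saturated ring is expected to lower the number in this assay modestly, a 3.3-fold lower number from compound 2 to compound 3 (0.51 log units; beyond the scatter). Compound 3 is therefore estimated at 4 nM, with a range from 1.5 nM to 12 nM.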

Compound 3, half-maximal inhibitory concentration: 12 nM
Compound 3: middle estimate off by 3.0-fold (0.48 log units), on the low side; low and high end bracket the measured number.
By their numbers in this assay, from the lowest: compound 1; then compounds 3 and 2 (each within the scatter of the next).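

In this assay, piperidin-1-yl in place of the two-ring group at this position, next to the ring nitrogen, reads within the scatter (a 1.1-fold lower number from compound 2 to compound 3 (0.03 log units; within the scatter)), so this change separates neither compound. Piperidin-1-yl in place of 3-methylpyrrolidin-1-yl, by contrast, is a step beyond the scatter (a 6.0-fold higher number from compound 1 to compound 3 (0.78 log units; beyond the scatter)), which leaves compound 1 apart from the other two. Nothing at hand explains either step.

Going by these compounds, that step changes the ring and removes the methyl together, so the share of each stays open. Plain pyrrolidin-1-yl would separate them, and how a morpholine ring would read here also remains unknown.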